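The source may hold more compounds than are shown below. What is called first, only, known or untested is meant among the compounds shown, and "the series" means these compounds.

Compound 1 `CC(=O)c1nn(-c2ccc(Cl)cc2)/c(=N/c2nc(-c3c(C)n(C)n(-c4ccccc4)c3=O)cs2)s1` carries the shared core with an acetyl group and a chloro substituent. In a functional assay on HepG2 cells (Homo sapiens) for cytotoxicity, read by sulforhodamine B assay, with a stated time of 72 h (on this read-out higher numbers stand for weaker inhibition and lower numbers for stronger inhibition), compound 1 gives > 100000 nM, which is a limit of the assay rather than a number. Compound 1 thus stands at the limit of > 100000 nM in this assay, at which 2 of the 3 values shown sit. Compound 2 `CC(=O)c1nn(-c2ccc(C)cc2)/c(=N/c2nc(-c3c(C)n(C)n(-c4ccccc4)c3=O)cs2)s1` has methyl in place of chloro on an aromatic carbon, and in this assay compound 2 gives 31700 nM. That change amounts to an at least 3.1-fold lower number from compound 1 to compound 2 (0.49 log units; beyond the scatter). Compound 3 `CC(=O)c1nn(-c2ccc([N+](=O)[O-])cc2)/c(=N/c2nc(-c3c(C)n(C)n(-c4ccccc4)c3=O)cs2)s1` has nitro in place of chloro on an aromatic carbon. In this assay compound 3 gives > 100000 nM, again a limit of the assay. Accordingly the step is a step that the two limits leave unreadable from compound 1 to compound 3, while the step of an at least 3.1-fold higher number from compound 2 to compound 3 (0.49 log units; beyond the scatter) can be read.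

Compound 4 `CCOC(=O)c1nn(-c2ccc(Cl)cc2)/c(=N/c2nc(-c3c(C)n(C)n(-c4ccccc4)c3=O)cs2)s1` differs from compound 1 at a different place: ethoxy in place of methyl on a carbonyl carbon, so acetyl becomes ethoxycarbonyl. Going by the values given here, none of the measured steps touches the carbonyl carbon; all three vary the group on the aromatic carbon, so no measured step bears directly on this change. The expectation for compound 4 rests on compound 1 alone. Compound 4 is expected to remain near the limit in this assay, with a number no higher from compound 1 to compound 4 (the limit leaves the size open) meaning no step beyond the scatter. Compound 4 is estimated at 100000 nM, between 30000 nM and 300000 nM.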

Compound 4, half-maximal inhibitory concentration: > 100000 nM
Compound 4 was reported as a limit (the forecaster's own chance of this, stated with the estimate: 70%); the middle value lies on the limit itself.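

In this assay compound 4 gives > 100000 nM, a limit of the assay and not a number. Compound 1 also stands at a limit, so no step can be read between compound 1 and compound 4: the limit of > 100000 nM in this assay, at which 3 of the 4 values shown sit.

The compounds shown leave open what ethoxy in place of methyl on a carbonyl carbon does where this assay returns a number rather than a limit.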